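Chloro additions on the anilide ring of the amide series

The source may report more compounds than this note shows. Statements on the series, on what has been measured and on what is new or still open speak of the compounds shown alone.

Compound 1 `CCC(=O)N(c1ccc(F)cc1)C1CCCC1N(C)C` gives 5 mg/kg in a functional assay on the whole organism for positive allosteric modulation, with Mus musculus as the target; on this read-out lower numbers stand for an effect already at smaller amounts and higher numbers for an effect only at larger amounts of compound. Compound 2 `CCC(=O)N(c1ccc(F)c(Cl)c1)C1CCCC1N(C)C` differs from it in one place, (chloro in place of hydrogen on an aromatic carbon), and in this assay compound 2 gives 0.2 mg/kg; the step of a 25-fold lower number from compound 1 to compound 2 (1.40 log units; beyond the scatter) is the only measured step of this kind in the series. Compound 3 `CCC(=O)N(c1cc(Cl)cc(Cl)c1)C1CCCC1N(C)C` carries two chloro groups; the difference between its core and the core of compound 1 is not broken down here. In this assay compound 3 gives 0.9 mg/kg, which lies between the values of compound 1 and compound 2 and beyond the scatter of both.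

Compound 4 `CCC(=O)N(c1cc(Cl)c(Cl)c(Cl)c1)C1CCCC1N(C)C` is not yet measured and differs from compound 3 by chloro in place of hydrogen on an aromatic carbon. Among the measured compounds shown here, this is the same kind of change as the one from compound 1 to compound 2, but not the same: there the chloro entered ortho to a fluoro group and meta to a large group, here it enters ortho to two chloro groups and para to a large group. A smaller step is expected this time, a 1.8-fold lower number from compound 3 to compound 4 (0.26 log units; within the scatter), because compound 3 already gives 0.9 mg/kg in this assay. Compound 4 is therefore expected to give about 0.5 mg/kg in this assay. For compound 4 the expected range runs from 0.1 mg/kg to 2 mg/kg.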

Compound 4, dose for half-maximal effect: 4 mg/kg
Beside the measured number, compound 4's estimate is 8.0-fold (0.90 log units) below it; the whole stated range lies below it.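

In this assay, chloro in place of hydrogen on an aromatic carbon now gives a 4.4-fold higher number from compound 3 to compound 4 (0.65 log units; beyond the scatter), which runs opposite to the earlier step: the same change on two cores in this assay, a 25-fold lower number (1.40 log units; beyond the scatter) from compound 1 to compound 2 and a 4.4-fold higher number (0.65 log units; beyond the scatter) from compound 3 to compound 4, 110-fold (2.05 log units) apart, beyond the scatter of two such steps

The effect of this change therefore does not carry from the core of compound 1 to the core of compound 3, in either direction or size, and a gain on one core gives no estimate for the other. What the two steps do not show is the reason for the reversal: in compound 4 the chloro enters ortho to two chloro groups and para to a large group, so the place of the new chloro and the surrounding core change together, and two steps cannot separate them.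

From the compounds shown here alone, it remains open how a bromo or methoxy group would read in that same place on the core of compound 3. Also open, going by these compounds, is whether either chloro step would hold with a longer chain on the amide carbonyl or with a different amine in place of the dimethylamino group.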